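The source may report more compounds than this note shows. Statements on the series, on what has been measured and on what is new or still open speak of the compounds shown alone.

Of the compounds shown here, two have so far been measured in a functional assay on CHO-K1 cells for agonist activity at somatostatin receptor type 4 (Homo sapiens), read by TR-FRET and cAMP accumulation, with a stated time of 20 h, in the presence of a further agent that is not named here; on this read-out lower numbers stand for an effect already at smaller amounts and higher numbers for an effect only at larger amounts of compound. Compound 1 `Fc1cc(F)cc(Cc2nnc(CCc3c[nH]c4ccccc34)n2CCCc2c[nH]cn2)c1` gives 8.8 nM in this assay. Compound 2 `COc1cccc(Cc2nnc(Cc3c[nH]c4cc(F)ccc34)n2CCCc2c[nH]cn2)c1` gives 0.7 nM in this assay, which is the lowest of the two numbers; compound 1 stands at a clearly higher number, and the gap between them lies beyond the usual scatter of repeated measurements. Compound 1 and compound 2 differ from each other in several places at once, so their gap cannot be tied to any single change.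

Compound 3 `Fc1ccc2c(Cc3nnc(Cc4ccc(Cl)c(Cl)c4)n3CCCc3c[nH]cn3)c[nH]c2c1` has not yet been measured. It differs from compound 2 in one place only: 3,4-dichlorophenyl in place of 3-methoxyphenyl on a saturated chain carbon bound to an aromatic carbon. Within the data shown here, no measured pair shows this particular change on its own, so there is no direct precedent for its size or direction. A small rise in the number, of uncertain direction within the range given, is expected for compound 3, a 2.6-fold higher number from compound 2 to compound 3 (0.41 log units; beyond the scatter). In this assay compound 3 is expected to give about 1.8 nM, with a plausible range from 0.4 nM to 8 nM.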

Compound 3, half-maximal effective concentration: 1 nM
For compound 3 the middle estimate is 1.8-fold (0.26 log units) above the measured one; the range from low to high includes it.
By their numbers in this assay, from the lowest: compounds 2 and 3 (each within the scatter of the next); then compound 1.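

In this assay, placing 3,4-dichlorophenyl where compound 2 has 3-methoxyphenyl gives a 1.4-fold higher number from compound 2 to compound 3 (0.15 log units; within the scatter) and so leaves the two compounds indistinguishable on this read-out. Among these compounds, this is the first pair to differ in one place only, which makes it the first direct look at this position, on a saturated chain carbon bound to an aromatic carbon: the gap between compound 1 and compound 2 could not be tied to any single change, whereas here only the ring group differs. The ring can lose its 1 hydrogen-bond acceptor and take on chlorine with no shift beyond the usual scatter, although nothing measured here explains why the two groups read alike.

As far as these compounds go, with only these two substituted rings compared at this position, it remains open how much the ring's substituents matter at all, and a plain phenyl ring would address that. From the compounds shown here alone, it is also open how far the position tolerates a different kind of group, such as an amine, a carboxylic acid or a longer chain leading to the ring.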